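Nitro for Acetamido in a Growth-Inhibition Series

The source may hold more compounds than are shown below. What is called first, only, known or untested is meant among the compounds shown, and "the series" means these compounds.

In a functional assay on PC-3 cells (Homo sapiens) for inhibition, read by sulforhodamine B assay (on this read-out lower numbers stand for stronger inhibition of growth and higher numbers for weaker inhibition of growth), compound 2 (`CC(=O)Nc1ccc(CN2CCC=C(CCC(=O)NO)C2=O)cc1`) stands at > 10000 nM, which is a limit of the assay and not a number. Compound 1 (`COc1cccc(CN2CCC=C(CCC(=O)NO)C2=O)c1`) stands at > 10000 nM, likewise a limit. The picture so far is therefore set by the limit of > 10000 nM in this assay, at which 2 of the 3 values shown sit. Only compound 3 (`Cc1ccc(S(=O)(=O)Nc2ccc(CN3CCC=C(CCC(=O)NO)C3=O)cc2)cc1`) gives a number, 1800 nM. Among the measured compounds shown here, the single measured step is an at least 5.5-fold lower number from compound 2 to compound 3 (0.74 log units; beyond the scatter), with (4-methylphenyl)sulfonyl in place of acetyl on a nitrogen on an aromatic ring, and it lies beyond the scatter.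

Compound 4 (`O=C(CCC1=CCCN(Cc2ccc([N+](=O)[O-])cc2)C1=O)NO`) instead carries nitro in place of acetamido on an aromatic carbon. That step bears only loosely on this change, since compound 4 keeps no (4-methylphenyl)sulfonyl group, so the gain seen in an at least 5.5-fold lower number from compound 2 to compound 3 (0.74 log units; beyond the scatter) is not expected to carry over. The expected result is a number no higher from compound 2 to compound 4 (the limit leaves the size open), which is no change beyond the scatter, and the reading may again be only a limit. Compound 4 is estimated at 10000 nM, within a range of 3500 nM to 30000 nM.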

Compound 4, concentration for 50% growth inhibition: 3010 nM
The estimate for compound 4 lay 3.3-fold (0.52 log units) above the measured number, outside the stated range (below it).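

In this assay, the change on this aromatic carbon, para to a large group, gives an at least 3.3-fold lower number from compound 2 to compound 4 (0.52 log units; beyond the scatter). A number rather than a limit at this position therefore does not depend on the (4-methylphenyl)sulfonyl group of compound 3, since compound 4 has none. The full size of the step cannot be given because compound 2 sits at a limit of the assay, which is the state of much of this small set: the limit of > 10000 nM in this assay, at which 2 of the 4 values shown sit.

Going by these compounds, whether an amine or a carboxylic acid in place of nitro on this aromatic carbon would also give a number stays open. So does whether the hydrogen-bond donor that leaves with acetamido, or the added hydrogen-bond acceptor that enters with nitro, has any part in the step.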